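Hydroxy on the triazole isopropyl of the urea series

The source may hold more compounds than are shown below. What is called first, only, known or untested is meant among the compounds shown, and "the series" means these compounds.

Two ureas have been measured so far, both built on the same left-hand part, and they differ only in the right-hand portion of the urea. In an assay on isolated protein for inhibition of mitogen-activated protein kinase kinase kinase 6 (Homo sapiens) (on this read-out higher numbers stand for weaker inhibition and lower numbers for stronger inhibition), compound 1 `CC(C)n1cnnc1-c1cccc(NC(=O)Nc2ccc(-c3ccn(C)n3)cn2)n1` gives 2780 nM. In this assay compound 2 `CC(C)n1cnnc1-c1cccc(NC(=O)Nc2nccc3ccccc23)n1` gives 201 nM. Compound 2 thus stands at the lowest of the two numbers on record, and its gap to compound 1 lies beyond the usual scatter of this read-out.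

Compound 3 `C[C@H](CO)n1cnnc1-c1cccc(NC(=O)Nc2nccc3ccccc23)n1` keeps the whole of compound 2 and alters one place: hydroxy in place of hydrogen on a saturated chain carbon, two bonds along the chain from an aromatic nitrogen. Within the data shown here, no measured pair shows this change, so its size is unknown here and nothing in the recorded numbers points to a direction. A step within or close to the scatter is expected, with no clear sign either way.

On that basis compound 3 is expected to give about 250 nM in this assay, with a plausible range from 80 nM to 800 nM. The expected step of a 1.2-fold higher number from compound 2 to compound 3 (0.09 log units; within the scatter) is accordingly small.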

Compound 3, half-maximal inhibitory concentration: 264 nM
For compound 3 the middle estimate is 1.1-fold (0.02 log units) below the measured one, and the stated range covers the measured number.
By their numbers in this assay, from the lowest: compounds 2 and 3 (each within the scatter of the next); then compound 1.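

In this assay, among these compounds, hydroxy in place of hydrogen on a saturated chain carbon, two bonds along the chain from an aromatic nitrogen, gives a 1.3-fold higher number from compound 2 to compound 3 (0.12 log units; within the scatter), the first reading of any change at this position. The position therefore accepts isopropyl to 1-(hydroxymethyl)ethyl with no step beyond the scatter, although this rests on a single pair carrying the right-hand portion of compound 2. No supporting evidence bears on this result, so the flat step remains an observation without an explanation.

As far as these compounds go, it remains open whether an amine or a carboxylic acid in place of the hydroxy, or a longer chain bearing the hydroxy, would also stay within the scatter of compound 2 at 201 nM. Also open, from the compounds shown here alone, are the mirror-image form of the 1-(hydroxymethyl)ethyl group and whether the same change would give a similarly small step on the right-hand portion of compound 1, which stands at 2780 nM.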